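From ethoxy to diethylamino on a shared core

A few compounds are considered here, and "the series" means these few. Any claim that something is new, unique, unknown or untested is made for them only; others in the source may bear on it.

Measured in a functional assay on HeLa cells (Homo sapiens) for antiproliferative activity, read by WST assay, with a stated time of 24 h; on this read-out lower numbers stand for stronger inhibition and higher numbers for weaker inhibition:
- compound 1 `C=C[C@]1(C)CC[C@@H](C(=C)COCC)C[C@H]1C(=C)C` gives 106000 nM
- compound 2 `C=C[C@]1(C)CC[C@@H](C(=C)CNC(C)C)C[C@H]1C(=C)C` gives 40 nM
- compound 3 `C=C[C@]1(C)CC[C@@H](C(=C)CNC2CCCC2)C[C@H]1C(=C)C` gives 520 nM

Compound 1 has the highest of these three numbers. Compound 4 `C=C[C@]1(C)CC[C@@H](C(=C)CN(CC)CC)C[C@H]1C(=C)C` keeps the core of compound 1 but carries diethylamino in place of ethoxy on a saturated chain carbon bound to a double-bonded chain carbon. Among the measured compounds shown here, two measured steps bear on this change, each replacing ethoxy with an amino group, and both are large (a 2700-fold lower number from compound 1 to compound 2 (3.42 log units; beyond the scatter); a 200-fold lower number from compound 1 to compound 3 (2.31 log units; beyond the scatter)). The two amines also differ clearly from each other (a 13-fold higher number from compound 2 to compound 3 (1.11 log units; beyond the scatter)), and neither carries diethylamino, so the size remains uncertain. A large step to a lower number is therefore expected (a 130-fold lower number from compound 1 to compound 4 (2.12 log units; beyond the scatter)). Compound 4 is estimated at 800 nM in this assay (expected range 60 nM to 15000 nM).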

Compound 4, half-maximal inhibitory concentration: 14400 nM
Compound 4: middle estimate off by 18-fold (1.26 log units), on the low side; low and high end bracket the measured number.
By their numbers in this assay, from the lowest: compound 2; then compound 3; then compound 4; then compound 1.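

In this assay, replacing ethoxy with an amino group at this place does not by itself bring the large drop seen with the earlier amines, as diethylamino gives a smaller step (a 7.4-fold lower number from compound 1 to compound 4 (0.87 log units; beyond the scatter)). The groups on the amine nitrogen matter greatly here, with diethylamino separated clearly from both cyclopentylamino (a 28-fold higher number from compound 3 to compound 4 (1.44 log units; beyond the scatter)) and isopropylamino (a 360-fold higher number from compound 2 to compound 4 (2.56 log units; beyond the scatter)). No available evidence accounts for this spread.

The compounds shown leave open how dimethylamino, piperidinyl or morpholinyl would fare at this place.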